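The source may hold more compounds than are shown below. What is called first, only, known or untested is meant among the compounds shown, and "the series" means these compounds.

Compound 1 `O=C1c2c[n+]([O-])c3ccccc3c2C(=O)c2c1c1ccccc1n2CCCCn1ccnc1` shows the lowest number of the three measured compounds in a functional assay on MDA-MB-231 cells (Homo sapiens) for cytotoxicity, read by MTT assay, with a stated time of 72 h (a lower number here means a stronger inhibitor, a higher number a weaker inhibitor), where compound 1 gives 210 nM. Compound 2 `CC1(C)OCC(Cn2cc(Cn3c4c(c5ccccc53)C(=O)c3c[n+]([O-])c5ccccc5c3C4=O)nn2)O1` sits within the scatter of it, giving 230 nM in this assay, so no order between compound 1 and compound 2 can be read. Compound 3 `CN1CCN(CCCCCCn2c3c(c4ccccc42)C(=O)c2c[n+]([O-])c4ccccc4c2C3=O)CC1` stands apart: in this assay compound 3 gives 2400 nM, and the step of an 11-fold higher number from compound 1 to compound 3 (1.06 log units; beyond the scatter) is the only large one among these compounds.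

Compound 4 `CN1CCN(CCCCCn2c3c(c4ccccc42)C(=O)c2c[n+]([O-])c4ccccc4c2C3=O)CC1` is not yet measured. Its difference from compound 1 is (4-methylpiperazin-1-yl)methyl in place of 1H-imidazol-1-yl on a saturated chain carbon, four bonds along the chain from an aromatic nitrogen. Going by the values given here, the one measured step that bears on this change is the replacement of the same five-membered ring by the same six-membered ring on a chain of different length, and it was large, an 11-fold higher number from compound 1 to compound 3 (1.06 log units; beyond the scatter). A rise of similar size in this assay is therefore expected for compound 4, an 8.6-fold higher number from compound 1 to compound 4 (0.93 log units; beyond the scatter). Compound 4 is estimated at 1800 nM in this assay, with a range from 600 nM to 5000 nM.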

Compound 4, half-maximal inhibitory concentration: 2270 nM
For compound 4 the middle estimate is 1.3-fold (0.10 log units) below the measured one, and the stated range covers the measured number.
By their numbers in this assay, from the lowest: compounds 1 and 2 (each within the scatter of the next); then compounds 4 and 3 (each within the scatter of the next).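

In this assay, the piperazine result now holds on a second chain: with (4-methylpiperazin-1-yl)methyl in place of 1H-imidazol-1-yl on a saturated chain carbon, the outcome is (an 11-fold higher number from compound 1 to compound 4 (1.03 log units; beyond the scatter)). The large rise seen earlier is therefore not confined to compound 3, and changing the chain that carries the 4-methylpiperazin-1-yl group moves the number only within the scatter (a 1.1-fold lower number from compound 3 to compound 4 (0.02 log units; within the scatter)). No measurement shown here gives a cause for the difference between the imidazole and the two piperazines.

Going by these compounds, it remains open whether the 1H-imidazol-1-yl group would keep its lower number on a longer chain. Also open, on these data alone, is whether another amine on the same chain, such as morpholine or dimethylamino, would fall with compound 1 or with the two piperazines.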